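Swapping the ring-free chain on the shared core

A few compounds are considered here, and "the series" means these few. Any claim that something is new, unique, unknown or untested is made for them only; others in the source may bear on it.

In an ADME assay on HOS cells (Homo sapiens) for cytotoxicity, read by luminescence and ATP content, with a stated time of 48 h (on this read-out higher numbers stand for lower toxicity in this test and lower numbers for higher toxicity in this test), compound 3 (`Nc1c(C(=O)NCc2ccc(F)cc2F)c(=O)n(O)c2ncc(CCCOCCO)cc12`) gives > 250000 nM as a limit of the assay and not a number. Among the measured compounds shown here, its place among the values so far is plain (the limit of > 250000 nM in this assay, at which 1 of the 3 values shown sits). In this assay compound 1 (`Nc1c(C(=O)NCc2ccc(F)cc2F)c(=O)n(O)c2ncc(CCCCc3ccccc3)cc12`) gives 13000 nM and compound 2 (`Nc1c(C(=O)NCc2ccc(F)cc2F)c(=O)n(O)c2ncc(CCc3ccccc3)cc12`) gives 18000 nM on the same read-out.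

In compound 4 (`CN(C)C(=O)/C=C/c1cnc2c(c1)c(N)c(C(=O)NCc1ccc(F)cc1F)c(=O)n2O`) the 3-(2-hydroxyethoxy)propyl gives way to 2-(dimethylcarbamoyl)ethenyl on an aromatic carbon (2-(dimethylcarbamoyl)ethenyl in place of 3-(2-hydroxyethoxy)propyl on an aromatic carbon) and the shared core stays the same. The nearest guides are an at least 19-fold higher number from compound 1 to compound 3 (1.28 log units; beyond the scatter) and an at least 13-fold higher number from compound 2 to compound 3 (1.14 log units; beyond the scatter) and both are large, while a 1.4-fold higher number from compound 1 to compound 2 (0.14 log units; within the scatter) stays within the scatter. Compound 1 and compound 2 carry a phenyl on their chains, whereas the groups of compound 3 and compound 4 hold no ring, so compound 4 is expected to stay close to compound 3. The expected change is an at least 1.6-fold lower number from compound 3 to compound 4 (0.22 log units; that floor lies within the scatter) and it points, if at all, to a somewhat lower number. In this assay the estimate for compound 4 is 150000 nM with an expected range from 40000 nM to 250000 nM as its bounds.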

Compound 4, half-maximal cytotoxic concentration: > 250000 nM
Compound 4: only a limit was reported (the forecaster's own chance of this, stated with the estimate: 45%); at least 1.6-fold (0.22 log units) between middle value and limit.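

In this assay, compound 4 also gives a limit of the assay and not a number, so a second ring-free group on this aromatic carbon sits at the same ceiling, now with 2-(dimethylcarbamoyl)ethenyl and its 0 hydrogen-bond donors: the limit of > 250000 nM in this assay, at which 2 of the 4 values shown sit. The hydroxyl of 3-(2-hydroxyethoxy)propyl is therefore not required to reach that limit, and the chains with a phenyl stay clearly apart, with an at least 13-fold higher number from compound 2 to compound 4 (1.14 log units; beyond the scatter) and an at least 19-fold higher number from compound 1 to compound 4 (1.28 log units; beyond the scatter). The step from compound 3 to compound 4 cannot be read, since both values are limits.

From the compounds shown here alone, how far compound 3 and compound 4 lie beyond the limit stays open. Also open, going by these compounds, is whether a ring-free chain ending in an amine or a carboxylic acid would stay at this limit or fall toward the phenyl-bearing compounds.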